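A few compounds are considered here, and "the series" means these few. Any claim that something is new, unique, unknown or untested is made for them only; others in the source may bear on it.

In an ADME assay (liver) for pharmacokinetics, with Liver microsome (Homo sapiens) as the target, using microsomes (a lower number here means that the compound disappears faster, a higher number that the compound lasts longer), the three measured compounds stand as follows. Compound 1 `CCOc1cc(NC(=O)C2(NC(=O)c3ccc4c(C5CCCC5)c(-c5ncc(Cl)cn5)n(C)c4c3)CCC2)ccc1/C=C/C(=O)OCC(C)C` gives > 5 h, which is a limit of the assay rather than a number. Compound 2 `CCCCCCOC(=O)/C=C/c1ccc(NC(=O)C2(NC(=O)c3ccc4c(C5CCCC5)c(-c5ncc(Cl)cn5)n(C)c4c3)CCC2)cc1OCC` gives 17.9 h. Compound 3 `CCOc1cc(NC(=O)C2(NC(=O)c3ccc4c(C5CCCC5)c(-c5ncc(Cl)cn5)n(C)c4c3)CCC2)ccc1/C=C/C(=O)OCC(Cl)(Cl)Cl` gives > 5 h, again a limit of the assay.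

Going by the values given here, compound 2 therefore holds the only number in this set; the other two values sit at the limit of > 5 h in this assay, at which 2 of the 3 values shown sit. The steps from compound 1 to compound 2 a step that the limit leaves unreadable from compound 1 to compound 2, from compound 1 to compound 3 a step that the two limits leave unreadable from compound 1 to compound 3 and from compound 2 to compound 3 a step that the limit leaves unreadable from compound 2 to compound 3 cannot be sized, so the three changes at the ester carbon give no readable trend.

Compound 4 `CCOc1cc(NC(=O)C2(NC(=O)c3ccc4c(C5CCCC5)c(-c5ncc(Cl)cn5)n(C)c4c3)CCC2)ccc1/C=C/C(=O)OCC(=O)OC` differs from compound 2 in one place: methoxycarbonyl in place of pentyl on a saturated chain carbon bound to an oxygen next to a carbonyl group. Among the compounds with values here, none of the measured steps gives a readable size for a change at this position, so the expectation for compound 4 rests on compound 2 alone and carries wide uncertainty. The step of a 2.0-fold lower number from compound 2 to compound 4 (0.30 log units; within the scatter) is estimated as a modest shortening. For compound 4 a half-life of 9 h is expected, within a range of 2.5 h to 25 h, and a reported limit is quite possible.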

Compound 4, half-life: 2.1 h
Estimate against measurement, compound 4: 4.3-fold (0.63 log units) above; the measured number lies below the stated range.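

In this assay, this position now gives a step of readable size: methoxycarbonyl in place of pentyl on a saturated chain carbon bound to an oxygen next to a carbonyl group gives an 8.5-fold lower number from compound 2 to compound 4 (0.93 log units; beyond the scatter). The same group in place of trichloromethyl gives an at least 2.3-fold lower number from compound 3 to compound 4 (0.37 log units; beyond the scatter), and in place of isopropyl it gives an at least 2.3-fold lower number from compound 1 to compound 4 (0.37 log units; beyond the scatter), so compound 4 has the shortest half-life of the four compounds. The steps among compound 1, compound 2 and compound 3 still cannot be read, and the two steps to compound 4 that start from a limit are open-ended: the limit of > 5 h in this assay, at which 2 of the 4 values shown sit.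

The compounds shown leave open whether the shorter half-life belongs to the whole methoxycarbonyl group or to its carbonyl alone; a methoxymethyl group or a carboxylic acid at this place would separate the two. As far as these compounds go, how a plain ethyl chain compares with pentyl also remains open.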